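Triazolylsulfanyl in place of benzoxazolylsulfanyl on the amide chain

This account rests on a few compounds, and the source may have more. Where it says the series, first, only, none or still open, it means among the compounds named here.

Compound 3 `Cc1ccc2oc(SCC(=O)Nc3ccc(-c4nc(-c5ccccc5)c(-c5ccccc5)n4C)cc3)nc2c1` gives 15.5% in a functional assay on HT-29 cells (Homo sapiens) for cytotoxicity, read by MTT assay, with a stated time of 24 h, tested at 1.6 ug/mL (on this read-out higher numbers stand for a stronger effect at the one concentration tested and lower numbers for a weaker effect), the second highest of three numbers; compound 1 `Cn1c(-c2ccc(NC(=O)CCl)cc2)nc(-c2ccccc2)c1-c1ccccc1` with 14.4% lies nearest a number 1.1 percentage points higher from compound 1 to compound 3 (within the scatter), while compound 2 `Cn1c(-c2ccc(NC(=O)CSc3nc4ccccc4o3)cc2)nc(-c2ccccc2)c1-c1ccccc1` with 41% stands furthest a number 25.5 percentage points lower from compound 2 to compound 3 (beyond the scatter). Compound 4 `Cn1cnnc1SCC(=O)Nc1ccc(-c2nc(-c3ccccc3)c(-c3ccccc3)n2C)cc1` differs from compound 3 by 4-methyl-4H-1,2,4-triazol-3-yl in place of 5-methyl-1,3-benzoxazol-2-yl on a sulfur. For the measured compounds named here, no measured step exchanges one ring on that sulfur for another: the only steps known are a number 26.6 percentage points higher from compound 1 to compound 2 (beyond the scatter) and a number 1.1 percentage points higher from compound 1 to compound 3 (within the scatter), so a smaller ring may sit anywhere between those outcomes. With nothing pointing either way, the step of a number 2.5 percentage points higher from compound 3 to compound 4 (within the scatter) is expected to stay within the scatter. Compound 4 is therefore estimated at 18%, between 5% and 38%.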

Compound 4, a percentage reported as activity, at one concentration (the size of the read-out at that concentration, not a potency): 40.8%
The estimate for compound 4 lay 22.8 percentage points below the measured number, and the stated range ends below it.
By their numbers in this assay, from the lowest: compounds 1 and 3 (each within the scatter of the next); then compounds 4 and 2 (each within the scatter of the next).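

In this assay, the ring on the sulfur proves able to change the read-out, with a number 25.3 percentage points higher from compound 3 to compound 4 (beyond the scatter). Ring size alone does not set the level, since the smaller 4-methyl-4H-1,2,4-triazol-3-yl ring and the 1,3-benzoxazol-2-yl ring match, with a number 0.2 percentage points lower from compound 2 to compound 4 (within the scatter). Replacing chloro also raises the number here, with a number 26.4 percentage points higher from compound 1 to compound 4 (beyond the scatter), as it does for compound 2, while compound 3 goes against this pattern.

On these data alone, whether a carboxylic acid or a morpholine ring on the sulfur would hold this level remains open. No available evidence explains these differences.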